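A Methoxyphenyl Swap Judged Against Two Cell Readings

The source may hold more compounds than are shown below. What is called first, only, known or untested is meant among the compounds shown, and "the series" means these compounds.

Compound 2 `COc1ccc(-c2nc(SCC(=O)c3sc(-c4ccc(Cl)cc4)nc3C)[nH]c(=O)c2C#N)cc1` is the reference point here. In a functional assay on U-87MG ATCC cells for antiproliferative activity against U-87 MG (Homo sapiens), read by MTT assay, with a stated time of 48 h, tested at 100 uM (a lower number here means a stronger effect, a higher number a weaker effect of the compound at the concentration tested), compound 2 gives 16.6%, the lowest of the two numbers recorded, while compound 1 `COc1cccc(-c2nc(SCC(=O)c3sc(-c4ccccc4)nc3C)[nH]c(=O)c2C#N)c1` gives 21.8%, a reading that sits within the scatter of compound 2, so no order can be drawn between them. Compound 3 `COc1cccc(-c2nc(SCC(=O)c3sc(-c4ccc(Cl)cc4)nc3C)[nH]c(=O)c2C#N)c1` has not been measured. It differs from compound 2 in one respect: 3-methoxyphenyl in place of 4-methoxyphenyl on an aromatic carbon. For the measured compounds named here, no measured pair shows this change alone; the step from compound 2 to compound 3 is expected to stay within the scatter, in no particular direction. Compound 3 is therefore estimated at 20%, within a range from 10% to 32%. That estimate amounts to an expected a number 3.4 percentage points higher from compound 2 to compound 3 (within the scatter).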

Compound 3, a percentage reported as activity, at one concentration (the size of the read-out at that concentration, not a potency): 8.54%
Estimate against measurement, compound 3: 11.5 percentage points above; the measured number lies below the stated range.
By their numbers in this assay, from the lowest: compounds 3, 2 and 1 (each within the scatter of the next, the first and the last beyond it).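

In this assay, the swap to 3-methoxyphenyl in place of 4-methoxyphenyl alone gives a number 8.1 percentage points lower from compound 2 to compound 3 (within the scatter) and so sets no order between the two groups at this position. For the compounds shown here, with 3-methoxyphenyl held in place, chloro in place of hydrogen on an aromatic carbon gives a number 13.3 percentage points lower from compound 1 to compound 3 (beyond the scatter) and is the only single change here to pass the scatter, though only modestly. No evidence is available to explain either step. The compounds shown leave open whether an amine or a longer chain such as ethoxy would be tolerated in place of the methoxy group. Going by these compounds, whether the chloro step also holds alongside 4-methoxyphenyl remains open too.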